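The source may report more compounds than this note shows. Statements on the series, on what has been measured and on what is new or still open speak of the compounds shown alone.

Going by the values given here, compound 2 `OC1CCCN(c2nc(-c3cc(-c4ccon4)n(Cc4ccccc4F)n3)ncc2F)C1` gives 360 uL/min in an ADME assay on microsomes from liver (Rattus norvegicus) for pharmacokinetics (on this read-out lower numbers stand for slow clearance and higher numbers for fast clearance), the lowest of the two numbers measured so far, with compound 1 `Fc1ccccc1Cn1nc(-c2ncc(F)c(OCC3CC3)n2)cc1-c1ccon1` nearest at 450 uL/min. Compound 3 `OC1CCN(c2nc(-c3cc(-c4ccon4)n(Cc4ccccc4F)n3)ncc2F)CC1` differs from compound 2 in one place: 4-hydroxypiperidin-1-yl in place of 3-hydroxypiperidin-1-yl on an aromatic carbon. Among the compounds with values here, the only measured step, a 1.3-fold lower number from compound 1 to compound 2 (0.10 log units; within the scatter), exchanged a different group on the same aromatic carbon and stayed within the scatter. The present change is even smaller, a rearrangement of the same atoms within the entering ring, so nothing beyond the scatter is anticipated. For compound 3 the expected step is no change at the digits printed from compound 2 to compound 3 (within the scatter). Compound 3 is therefore estimated at 360 uL/min, between 200 uL/min and 650 uL/min.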

Compound 3, intrinsic clearance in a liver preparation (reported as CLH), per the amount of preparation that the assay uses: 390 uL/min
Compound 3: middle estimate off by 1.1-fold (0.03 log units), on the low side; low and high end bracket the measured number.
By their numbers in this assay, from the lowest: compounds 2, 3 and 1 (each within the scatter of the next).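

Shifting the hydroxyl within the ring, 4-hydroxypiperidin-1-yl in place of 3-hydroxypiperidin-1-yl, gives a 1.1-fold higher number from compound 2 to compound 3 (0.03 log units; within the scatter) in this assay, so this read-out does not separate the two ring isomers. Replacing cyclopropylmethoxy on the same aromatic carbon with 4-hydroxypiperidin-1-yl gives a 1.2-fold lower number from compound 1 to compound 3 (0.06 log units; within the scatter), so this second hydroxylated ring also stays within the scatter of compound 1. No other data bear on this result. Still open, as far as these compounds go, is whether plain piperidine, morpholine or a ring carrying an amine or a carboxylic acid at this place would move the number beyond the scatter.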